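Furan-2-ylmethyl in Place of Morpholine on an Amide Nitrogen

The compounds below may be only part of what the source reports. "The series", "measured", "known", "first", "only" and "open" are said of these compounds alone.

Compound 2 `COCOc1cc(/C=C/C(=O)OCC(=O)NN2CCOCC2)ccc1OCc1ccccc1` carries a morpholin-4-yl group on an amide-type nitrogen. In a functional assay on LS174T cells (Homo sapiens) for cytotoxicity, read by MTT assay, with a stated time of 72 h (a higher number here means a weaker inhibitor, a lower number a stronger inhibitor), compound 2 gives only a limit, > 200000 nM, so no number is known for it. Compound 1 `COCOc1cc(/C=C/C(=O)OCC(=O)Nc2ccc(OC)cc2)ccc1OCc1ccccc1` differs from compound 2 in one place, a 4-methoxyphenyl group standing on that same nitrogen. In this assay compound 1 also gives only a limit, > 200000 nM. The step that the two limits leave unreadable from compound 1 to compound 2 therefore cannot be read, because the limit of > 200000 nM in this assay, at which 2 of the 2 values shown sit: both values sit at the same limit, and the change between them may be large or nil.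

Compound 3 `COCOc1cc(/C=C/C(=O)OCC(=O)NCc2ccco2)ccc1OCc1ccccc1` has not yet been measured in this assay. Its difference from compound 2 is (furan-2-yl)methyl in place of morpholin-4-yl on an amide-type nitrogen. No measured step bears readably on this change; the one step known among these compounds is itself unreadable. The expected step of a number no higher from compound 2 to compound 3 (the limit leaves the size open) is accordingly none that can be told apart from scatter. Compound 3 is expected to give 200000 nM, within a range from 60000 nM to 500000 nM, and most probably only a limit again.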

Compound 3, half-maximal inhibitory concentration: > 200000 nM
Compound 3 was reported as a limit (the forecaster's own chance of this, stated with the estimate: 75%); the middle value lies on the limit itself.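

The steps linking compound 1, compound 2 and compound 3 cannot be read, so no new comparison comes from compound 3, because all three values are limits and not numbers: the limit of > 200000 nM in this assay, at which 3 of the 3 values shown sit. Going by these compounds, whether 4-methoxyphenyl, morpholin-4-yl and (furan-2-yl)methyl on the amide-type nitrogen differ at all in this assay stays open.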